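Replacing the Aniline Arm with Methylpiperazine

The source may report more compounds than this note shows. Statements on the series, on what has been measured and on what is new or still open speak of the compounds shown alone.

Of the compounds shown here, three sharing one core have been measured in a functional assay on HepG2 cells (Homo sapiens) for antiproliferative activity, read by CCK-8 assay, with a stated time of 72 h, tested at 8 uM; on this read-out higher numbers stand for a stronger effect at the one concentration tested and lower numbers for a weaker effect. Compound 1 `Cc1ccc(Nc2nc(Cl)nc3c2ncn3Cc2ccc(C(=O)Nc3ccccc3N)cc2)cc1` gives 82%, compound 2 `Nc1ccccc1NC(=O)c1ccc(Cn2cnc3c(Nc4ccccc4)nc(Cl)nc32)cc1` gives 74.8%, and compound 3 `Nc1ccccc1NC(=O)c1ccc(Cn2cnc3c(Nc4cccc(Cl)c4)nc(Cl)nc32)cc1` gives 66.7%. The step of a number 15.3 percentage points lower from compound 1 to compound 3 (beyond the scatter) is beyond the scatter, whereas a number 8.1 percentage points lower from compound 2 to compound 3 (within the scatter) is within it, so compound 3 sits at the low end of the three without clearly separating from compound 2. Compound 4 `CN1CCN(c2nc(Cl)nc3c2ncn3Cc2ccc(C(=O)Nc3ccccc3N)cc2)CC1` differs from compound 3 in one place: 4-methylpiperazin-1-yl in place of (3-chlorophenyl)amino on an aromatic carbon. For the measured compounds named here, no measured step covers such an exchange; the known steps of a number 7.2 percentage points lower from compound 1 to compound 2 (within the scatter) and a number 8.1 percentage points lower from compound 2 to compound 3 (within the scatter) only alter substituents on the aromatic ring that now leaves, so the new arm is untested ground. Compound 4 is therefore estimated at 55%, between 30% and 80%. The expected step of a number 11.7 percentage points lower from compound 3 to compound 4 (beyond the scatter) is modest and uncertain in direction.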

Compound 4, a percentage reported as inhibition, at one concentration (the size of the read-out at that concentration, not a potency): 75%
Compound 4: middle estimate off by 20 percentage points, on the low side; measured number inside the range.
By their numbers in this assay, from the lowest: compounds 3, 2, 4 and 1 (each within the scatter of the next, the first and the last beyond it).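

In this assay the place on the shared core that held an arylamino arm also takes 4-methylpiperazin-1-yl, with a number 8.3 percentage points higher from compound 3 to compound 4 (within the scatter) and a number 0.2 percentage points higher from compound 2 to compound 4 (within the scatter) and a number 7 percentage points lower from compound 1 to compound 4 (within the scatter) as the three steps. Among these compounds, then, neither an aromatic ring in this arm nor a hydrogen-bond donor on it is required to keep the effect at this one concentration. Nothing available explains this result.

As far as these compounds go, whether a morpholine ring or an open-chain dimethylamino group would fare the same at this position remains open.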